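Octyl to 4-bromobenzyl on a Boc-piperazine Chalcone Scaffold

The compounds below may be only part of what the source reports. "The series", "measured", "known", "first", "only" and "open" are said of these compounds alone.

Measured compounds:
compound 1, `CCCCCCCCn1cc(/C=C/C(=O)c2ccc(NC(=O)CN3CCN(c4ccccc4F)CC3)cc2)nn1`, 68600 nM
compound 2, `CCCCCCCCn1cc(/C=C/C(=O)c2ccc(NC(=O)CN3CCN(C(=O)OC(C)(C)C)CC3)cc2)nn1`, 98400 nM

Of the compounds shown here, two have been measured in a functional assay on MCF7 cells (Homo sapiens) for inhibition, read by MTT assay; a lower number here means a stronger inhibitor, a higher number a weaker inhibitor. Compound 1 gives 68600 nM. Compound 2, which carries tert-butoxycarbonyl in place of 2-fluorophenyl on the amine nitrogen in the ring, gives 98400 nM; the step of a 1.4-fold higher number from compound 1 to compound 2 (0.16 log units; within the scatter) is within the scatter, so the two values are not distinguished.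

Compound 3, `CC(C)(C)OC(=O)N1CCN(CC(=O)Nc2ccc(C(=O)/C=C/c3cn(Cc4ccc(Br)cc4)nn3)cc2)CC1`, differs from compound 2 at a different place: 4-bromophenyl in place of heptyl on a saturated chain carbon bound to an aromatic nitrogen. Among the measured compounds shown here, no measured step touches this position, so nothing measured bears directly on it; the one step on record, a 1.4-fold higher number from compound 1 to compound 2 (0.16 log units; within the scatter), concerns the piperazine substituent and gives no guidance here. Both measured values are weak, and without a relevant step there is no reason to expect a move beyond the scatter in either direction in this assay, though the uncertainty is wide. Compound 3 is therefore estimated at 70000 nM, with a range from 20000 nM to 250000 nM, corresponding to an expected step of a 1.4-fold lower number from compound 2 to compound 3 (0.15 log units; within the scatter).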

Compound 3, half-maximal inhibitory concentration: 31000 nM
Compound 3: middle estimate off by 2.3-fold (0.35 log units), on the high side, and the stated range covers the measured number.
By their numbers in this assay, from the lowest: compound 3; then compounds 1 and 2 (each within the scatter of the next).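

In this assay, among the compounds shown here, the change from heptyl to 4-bromophenyl on a saturated chain carbon bound to an aromatic nitrogen gives a 3.2-fold lower number from compound 2 to compound 3 (0.50 log units; beyond the scatter), a modest step but one beyond the scatter, whereas the only earlier step, a 1.4-fold higher number from compound 1 to compound 2 (0.16 log units; within the scatter), concerned the piperazine substituent and stayed within it. For the compounds shown here, this is the first sign that the number responds to a change at this position, here the loss of a ringless chain and the arrival of a six-membered aromatic ring carrying bromine, with the heavy-atom count unchanged. Nothing on hand accounts for why the number falls with this change.

The compounds shown leave open whether the ring, the bromine or the two together go with the lower number, a question that an unsubstituted benzyl, a 4-chlorobenzyl or a shorter chain such as butyl at this place would help to separate. They also leave open whether 4-bromobenzyl would bring a similar step with 2-fluorophenyl in place of tert-butoxycarbonyl on the piperazine.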